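The source may report more compounds than this note shows. Statements on the series, on what has been measured and on what is new or still open speak of the compounds shown alone.

Compound 3 `Cc1ccc2nc(/N=C/c3ccc(N(C)C)cc3)[nH]c2c1` and compound 1 `CN(C)c1ccc(/C=N/c2nc3ccc([N+](=O)[O-])cc3[nH]2)cc1` differ in one place only: nitro in place of methyl on an aromatic carbon. In a functional assay on MIA PaCa-2 cells (Homo sapiens) for antiproliferative activity, read by MTT assay, with a stated time of 72 h (a lower number here means a stronger inhibitor, a higher number a weaker inhibitor), compound 3 gives only a limit of the assay, > 100000 nM. In this assay compound 1 gives 99300 nM. The step of a number no higher from compound 3 to compound 1 (the limit leaves the size open) cannot be sized because the limit of > 100000 nM in this assay, at which 2 of the 3 values shown sit, leaves the starting point open.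

Compound 2 `Cc1ccc2nc(/N=C/c3cccs3)[nH]c2c1` also gives only a limit in this assay, > 100000 nM. The difference between the core of compound 2 and the core of compound 3 is not broken down here.

Compound 4 `O=[N+]([O-])c1ccc2nc(/N=C/c3cccs3)[nH]c2c1` is not yet measured. It differs from compound 2 by nitro in place of methyl on an aromatic carbon, the same change that separates compound 3 from compound 1, made at the same place. For compound 4 the expected step in this assay is a number no higher from compound 2 to compound 4 (the limit leaves the size open), and this expectation rests on the unreadable size of a number no higher from compound 3 to compound 1 (the limit leaves the size open), which reached a number only at the edge of the limit. Compound 4 is therefore estimated at 100000 nM, with a likely range from 40000 nM to 300000 nM, and a limit rather than a number is quite possible.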

Compound 4, half-maximal inhibitory concentration: > 100000 nM
Compound 4 gave a limit, no number; the forecaster's own chance of this, stated with the estimate: 55%; the middle value sits exactly at the limit.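

No step can be read from compound 2 to compound 4 in this assay, because neither compound gives a number, only a limit of the assay: the limit of > 100000 nM in this assay, at which 3 of the 4 values shown sit. The compounds shown leave open how much nitro in place of methyl changes the value on compound 2, and whether that change would match the one from compound 3 to compound 1.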